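A few compounds are considered here, and "the series" means these few. Any claim that something is new, unique, unknown or untested is made for them only; others in the source may bear on it.

Of the compounds shown here, two have been measured in a functional assay on RXF 393 cells (Homo sapiens) for inhibition, read by sulforhodamine B assay, with a stated time of 48 h, tested at 10 uM; a higher number here means more inhibition at the concentration tested (going by the name of the read-out), a lower number less inhibition. Compound 1 `O=Cc1ccc(-c2cn3ccnc3c(-c3ccc4ncn(C5CCCCC5)c4c3)n2)cc1` gives 25% in this assay. Compound 2 `c1cn2cc(-c3ccc4c(c3)ncn4C3CCCCC3)nc(-c3ccc4ncn(C5CCCCC5)c4c3)c2n1` gives 37.4% in this assay, the higher of the two numbers, with compound 1 standing lower by a margin beyond the usual scatter. Compound 3 `c1ccc(Cn2cnc3ccc(-c4nc(-c5ccc6c(c5)ncn6C5CCCCC5)cn5ccnc45)cc32)cc1` is not yet measured; it differs from compound 2 by benzyl in place of cyclohexyl on an aromatic nitrogen. Among the measured compounds shown here, no measured pair shows this change, so its effect is unknown here. The step of a number 2.4 percentage points lower from compound 2 to compound 3 (within the scatter) is expected to be small, in either direction, and not beyond the scatter. Compound 3 is estimated at 35%, with a range from 15% to 55%.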

Compound 3, a percentage reported as inhibition, at one concentration (the size of the read-out at that concentration, not a potency): -76.9%
Estimate against measurement, compound 3: 111.9 percentage points above, outside the stated range (below it).
By their numbers in this assay, from the lowest: compound 3; then compound 1; then compound 2.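

In this assay, benzyl in place of cyclohexyl on an aromatic nitrogen gives a large step, a number 114.3 percentage points lower from compound 2 to compound 3 (beyond the scatter), so this position is not indifferent to the group it carries. Compound 3 also reads on the negative side of the scale, where neither earlier compound stands. No measurement at hand bears on the reason for this step.

This single pair does not separate the aromatic ring from the added carbon of benzyl. Phenyl or cyclohexylmethyl on the same nitrogen would address that, and whether an amine-bearing chain there gives a higher, lower or level number in this assay remains open.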